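The source may report more compounds than this note shows. Statements on the series, on what has been measured and on what is new or still open speak of the compounds shown alone.

In an in vitro ADME assay on microsomes from liver (Homo sapiens) for metabolic stability (a higher number here means faster removal of the compound, a lower number slower removal), compound 1 `NC(=O)c1n[nH]c(-c2nc(Cc3ccccc3F)c3ccccn23)n1` gives < 8 mL.min-1.g-1, which is a limit of the assay and not a number. Compound 2 `Cc1ncc(Cc2nc(-c3nc(C(F)(F)F)n[nH]3)n3cccc(F)c23)cn1`, which carries trifluoromethyl, gives < 8 mL.min-1.g-1, also a limit. Compound 3 `Fc1ccccc1Cc1nc(-c2nc(C(F)(F)C(F)(F)F)n[nH]2)n2ccccc12` has 1,1,2,2,2-pentafluoroethyl in place of carbamoyl on an aromatic carbon of the five-membered aromatic ring with 3 nitrogen: 1,1,2,2,2-pentafluoroethyl in place of carbamoyl on an aromatic carbon. Among the measured compounds shown here, no measured pair differs in one place only, so the expectation is loose: a small rise in this assay, possibly none beyond the usual scatter. The estimated step is an at least 1.1-fold higher number from compound 1 to compound 3 (0.05 log units; that floor lies within the scatter). For compound 3 the expected value is 9 mL.min-1.g-1, with an estimated range of 4 mL.min-1.g-1 to 22 mL.min-1.g-1.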

Compound 3, intrinsic clearance in microsomes: 92 mL.min-1.g-1
The estimate for compound 3 lay 10-fold (1.01 log units) below the measured number, outside the stated range (above it).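

In this assay, putting 1,1,2,2,2-pentafluoroethyl in place of carbamoyl on an aromatic carbon gives an at least 11-fold higher number from compound 1 to compound 3 (1.06 log units; beyond the scatter). The earlier compounds shown here gave only limits, whereas compound 3 shows that a change at this single place can bring a clearly measurable value. The step is a floor and not an exact size, since the value of compound 1 is a limit: the limit of < 8 mL.min-1.g-1 in this assay, at which 2 of the 3 values shown sit.

Whether the rise comes from gaining the fluorinated chain or from losing carbamoyl stays unresolved, as compound 2 differs from compound 1 in more than one place. On these data alone, what an unfluorinated ethyl chain or a carboxylic acid would do on this carbon also remains open.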